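Chloro to Dimethylamino: Cytotoxicity Expected to Stay at a Limit

The source may hold more compounds than are shown below. What is called first, only, known or untested is meant among the compounds shown, and "the series" means these compounds.

Compound 1 `O=C(O)/C=C/[C@H]1C[C@@H](O)[C@@H](O)C1`: in an ADME assay on S2 cells (Drosophila melanogaster) for cytotoxicity, read by MTT assay (a higher number here means that more compound is needed for the effect, a lower number that less compound is needed), compound 1 gives > 350000 nM, a limit of the assay.
Compound 2 `O=C(/C=C/[C@H]1C[C@@H](O)[C@@H](O)C1)Nc1ccc(Cl)cc1`: in this assay compound 2 gives > 180000 nM, again a limit.
Compound 3 `O=C(/C=C/[C@H]1C[C@@H](O)[C@@H](O)C1)Nc1ccc(Cl)c(Cl)c1`: in this assay compound 3 gives > 160000 nM, also a limit.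

Compound 2 therefore stands only at a limit, as do the two other values shown (the limit of > 180000 nM in this assay, at which 1 of the 3 values shown sits). The change to compound 4 `CN(C)c1ccc(NC(=O)/C=C/[C@H]2C[C@@H](O)[C@@H](O)C2)cc1` is dimethylamino in place of chloro on an aromatic carbon. Going by the values given here, the one measured step at this position, a step that the two limits leave unreadable from compound 2 to compound 3, cannot be read because the limit of > 180000 nM in this assay, at which 1 of the 3 values shown sits, and the limit of > 160000 nM in this assay, at which 1 of the 3 values shown sits, are both limits. No readable step is therefore expected, and the step that the limit leaves unreadable from compound 2 to compound 4 is expected to be none beyond the scatter. Compound 4 is estimated at 200000 nM, within 100000 nM to 400000 nM.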

Compound 4, half-maximal effective concentration: > 170000 nM
Compound 4: only a limit was reported; the forecaster's own chance of this, stated with the estimate: 85%; the middle value lies beyond the limit too.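

Compound 2 and compound 4 both stand only at limits, so no step can be read between them. The compounds shown leave open what concentration of any of them produces the effect in this assay.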